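From 4-chlorophenyl to 4-fluorophenyl: a small expected step

This account rests on a few compounds, and the source may have more. Where it says the series, first, only, none or still open, it means among the compounds named here.

Of the compounds shown here, three sharing one core have been measured in a functional assay on MCF7 cells (Homo sapiens) for inhibition, read by CCK-8 assay, with a stated time of 72 h (on this read-out lower numbers stand for stronger inhibition and higher numbers for weaker inhibition), and they differ only in the group on one aromatic carbon. Compound 1 (`Cc1ccc(NS(=O)(=O)c2cccc(CCCCCCNC(=O)/C=C/c3cccnc3)c2)cc1`), with methyl, gives 1.97 nM. Compound 2 (`CC(C)(C)c1ccc(NS(=O)(=O)c2cccc(CCCCCCNC(=O)/C=C/c3cccnc3)c2)cc1`), with tert-butyl, gives 26.3 nM. Compound 3 (`O=C(/C=C/c1cccnc1)NCCCCCCc1cccc(S(=O)(=O)Nc2ccc(Cl)cc2)c1`), with chloro, gives 5.94 nM, the middle number of the three.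

The next compound, compound 4 (`O=C(/C=C/c1cccnc1)NCCCCCCc1cccc(S(=O)(=O)Nc2ccc(F)cc2)c1`), carries fluoro in place of chloro on that carbon, para to a large group: fluoro in place of chloro on an aromatic carbon. Within the data shown here, no measured compound carries fluoro, so the expectation must be drawn from the neighbouring steps. The exchange of methyl for chloro is modest, a 3.0-fold higher number from compound 1 to compound 3 (0.48 log units; beyond the scatter). The tert-butyl steps are wider, a 13-fold higher number from compound 1 to compound 2 (1.13 log units; beyond the scatter) and a 4.4-fold lower number from compound 2 to compound 3 (0.65 log units; beyond the scatter). Both of those involve the bulkiest group named here, so they bear less directly on an exchange of one halogen for another. The closest guide is therefore the modest step, and the span from compound 1 to compound 3 offers the likeliest territory for the new value. A small step toward a lower number is expected, probably within the scatter: a 1.5-fold lower number from compound 3 to compound 4 (0.17 log units; within the scatter). In this assay, compound 4 is estimated at 4 nM, with an expected range of 1.5 nM to 11 nM.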

Compound 4, half-maximal inhibitory concentration: 0.91 nM
Estimate against measurement, compound 4: 4.4-fold (0.64 log units) above, and the stated range ends above it.
By their numbers in this assay, from the lowest: compound 4; then compound 1; then compound 3; then compound 2.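

In this assay the exchange of one halogen for the other on this carbon, para to a large group, turns out to be no minor edit: the step is a 6.5-fold lower number from compound 3 to compound 4 (0.81 log units; beyond the scatter) even though only one heavy atom leaves and one enters. Fluoro also goes past methyl, with a 2.2-fold lower number from compound 1 to compound 4 (0.34 log units; beyond the scatter) as the step, so compound 4 now holds the lowest number of the four, and the widest gap at this position grows to a 29-fold lower number from compound 2 to compound 4 (1.46 log units; beyond the scatter) in this series. The order on this carbon is therefore fluoro, methyl, chloro, tert-butyl, with the two halogens falling on opposite sides of methyl, something the first three compounds could not reveal.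

Nothing measured here accounts for the gap between the two halogens. From the compounds shown here alone, whether bromo, a plain hydrogen or a methoxy group on this carbon would continue or break that order stays open, as does whether fluoro would keep its place in the order with a shorter chain in place of the present one.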